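The compounds below may be only part of what the source reports. "The series", "measured", "known", "first", "only" and "open" are said of these compounds alone.

Measured compounds:
compound 1 `COc1ccc(-c2nc3cccc(-c4cc(OC)c(OC)c(OC)c4)c3o2)cc1F` — 1800 nM
compound 2 `COc1cc(-c2cccc3nc(-c4ccc(Cl)cc4)oc23)cc(OC)c1OC` — 5600 nM

For the measured compounds named here, in a functional assay on A549 cells (Homo sapiens) for antiproliferative activity, read by MTT assay, with a stated time of 48 h (on this read-out higher numbers stand for weaker inhibition and lower numbers for stronger inhibition), compound 1 stands at the lowest of the two numbers; the only other measurement lies above it, a 3.1-fold higher number from compound 1 to compound 2 (0.49 log units; beyond the scatter). Compound 3 `COc1cc(-c2cccc3nc(-c4cccc(N)c4)oc23)cc(OC)c1OC` carries 3-aminophenyl in place of 3-fluoro-4-methoxyphenyl on an aromatic carbon. Going by the values given here, the single measured step that bears on this change, a 3.1-fold higher number from compound 1 to compound 2 (0.49 log units; beyond the scatter), was a modest rise when the same 3-fluoro-4-methoxyphenyl was replaced, so a modest rise, or none beyond the scatter, is expected here as well. Compound 3 is therefore estimated at 3200 nM, between 1300 nM and 8000 nM, which means an expected step of a 1.8-fold higher number from compound 1 to compound 3 (0.25 log units; within the scatter).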

Compound 3, half-maximal inhibitory concentration: 4700 nM
For compound 3 the middle estimate is 1.5-fold (0.17 log units) below the measured one; the range from low to high includes it.
By their numbers in this assay, from the lowest: compound 1; then compounds 3 and 2 (each within the scatter of the next).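

With compound 3, a second replacement of the 3-fluoro-4-methoxyphenyl in this assay gives weaker inhibition, with a 2.6-fold higher number from compound 1 to compound 3 (0.42 log units; beyond the scatter), so the rise is not confined to 4-chlorophenyl. The two replacements are not separated, with a 1.2-fold lower number from compound 2 to compound 3 (0.08 log units; within the scatter), even though 3-aminophenyl brings a hydrogen-bond donor that 4-chlorophenyl lacks. Nothing available explains these results. The compounds shown leave open whether the methoxy group or the fluorine of compound 1 accounts for its lower number. They also leave open how a 3-hydroxyphenyl or 4-aminophenyl would read here.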